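The source may report more compounds than this note shows. Statements on the series, on what has been measured and on what is new or still open speak of the compounds shown alone.

Measured compounds:
- Compound 1, `Cc1ccc(NC(=O)c2cccc(/C=C3\CC(=O)N(c4ccccc4)C3=O)c2)cc1C`. In an ADME assay on HCT-116 cells (Homo sapiens) for cytotoxicity, read by MTT assay, with a stated time of 72 h (on this read-out higher numbers stand for weaker inhibition and lower numbers for stronger inhibition), compound 1 gives > 100000 nM, which is a limit and not a number.
- Compound 2, `CCc1cccc(NC(=O)c2cccc(/C=C3\CC(=O)N(c4ccccc4)C3=O)c2)c1`. In this assay compound 2 gives 81200 nM.

Going by the values given here, compound 2 holds the only number in this assay. The value of compound 1 sits at the limit of > 100000 nM in this assay, at which 1 of the 2 values shown sits. Among the compounds with values here, the single measured step, an at least 1.2-fold lower number from compound 1 to compound 2 (0.09 log units; that floor lies within the scatter), exchanges one substituted phenyl for another on the amide-type nitrogen and does not rise above the scatter.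

Compound 3, `O=C(NCc1ccccc1)c1cccc(/C=C2\CC(=O)N(c3ccccc3)C2=O)c1`, is not yet measured. It differs from compound 2 by benzyl in place of 3-ethylphenyl on an amide-type nitrogen. Within the data shown here, the only measured step bears on it loosely, since it kept an aryl group on the nitrogen, whereas compound 3 carries benzyl there; no step of that kind has been measured. The expected step is a 1.1-fold higher number from compound 2 to compound 3 (0.04 log units; within the scatter), no change beyond the scatter. Compound 3 is estimated at 90000 nM, with a range from 40000 nM to 200000 nM, and a fair chance that only a limit is reported.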

Compound 3, half-maximal inhibitory concentration: > 100000 nM
Compound 3: only a limit was reported; the forecaster's own chance of this, stated with the estimate: 45%; at least 1.1-fold (0.04 log units) between middle value and limit.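

As far as these compounds go, on the amide-type nitrogen, benzyl in place of 3-ethylphenyl gives an at least 1.2-fold higher number from compound 2 to compound 3 (0.09 log units; that floor lies within the scatter) in this assay, so this first change away from a directly attached aryl group shows no stronger inhibition, while the true size of the step remains unknown. The step from compound 1 to compound 3 joins two limits and cannot be read. Compound 3 gives only a limit, not a number, and it is the second compound in the series to do so: the limit of > 100000 nM in this assay, at which 2 of the 3 values shown sit.

From the compounds shown here alone, it remains open whether a longer chain such as phenethyl on this nitrogen would give a number clear of that limit. The same holds for a chain ending in an amine or a carboxylic acid, or for a benzyl group bearing a substituent on its ring.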